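Hydrogen in place of the aryl ring on the ring nitrogen

The source may report more compounds than this note shows. Statements on the series, on what has been measured and on what is new or still open speak of the compounds shown alone.

Measured compounds:
Compound 1 `Cc1cc(/C=C2\S/C(=N\c3ccccc3)N(C3CCCCC3)C2=O)c(C)n1-c1ccccc1` sits at a limit in an ADME assay on L6 cells (Rattus norvegicus) for cytotoxicity, read by microscopy and resazurin assay, with a stated time of 72 h (a lower number here means that less compound is needed, a higher number that more compound is needed for the effect), > 200000 nM.
Compound 2 `Cc1cc(/C=C2\S/C(=N\c3ccccc3)N(C3CCCCC3)C2=O)c(C)n1-c1ccc(C(F)(F)F)cc1` sits at a limit, > 170000 nM.
Compound 3 `Cc1cc(/C=C2\S/C(=N\c3ccccc3)N(C3CCCCC3)C2=O)c(C)n1-c1ccccc1C(F)(F)F` sits at a limit, > 170000 nM.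

All three values are limits of this assay, not numbers: the cells were not harmed up to the highest concentration tested. Compound 3 therefore stands on a limit, and the two other values shown are limits as well, as the limit of > 170000 nM in this assay, at which 2 of the 3 values shown sit, and the limit of > 200000 nM in this assay, at which 1 of the 3 values shown sits, record. Because of this, the steps among the measured compounds cannot be read: a step that the two limits leave unreadable from compound 1 to compound 2, a step that the two limits leave unreadable from compound 1 to compound 3 and a step that the two limits leave unreadable from compound 2 to compound 3. The evidence only shows that adding a trifluoromethyl group to the aromatic ring, or moving it from one position to another on that ring, left every compound beyond the reach of this assay.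

Compound 4 `Cc1cc(/C=C2\S/C(=N\c3ccccc3)N(C3CCCCC3)C2=O)c(C)[nH]1` differs from compound 3 in one place: hydrogen in place of 2-(trifluoromethyl)phenyl on an aromatic nitrogen. Within the data shown here, no measured step informs this change, since every step is hidden behind a limit. With nothing pointing to a readable change, compound 4 is expected to stay at or near the limit as well. The estimate for compound 4 is 200000 nM, with a range from 50000 nM to 600000 nM. This is expected to amount to a step that the limit leaves unreadable from compound 3 to compound 4, most likely again reported only as a limit.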

Compound 4, half-maximal effective concentration: 23000 nM
Compound 4: middle estimate off by 8.7-fold (0.94 log units), on the high side; measured number outside the range, below it.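

Taking the aryl ring off the ring nitrogen is the first change in this series that registers in this assay, with an at least 7.3-fold lower number from compound 3 to compound 4 (0.86 log units; beyond the scatter) and an at least 7.3-fold lower number from compound 2 to compound 4 (0.86 log units; beyond the scatter) and an at least 8.6-fold lower number from compound 1 to compound 4 (0.93 log units; beyond the scatter). Among these compounds, each of the three aryl groups, phenyl, 4-(trifluoromethyl)phenyl and 2-(trifluoromethyl)phenyl, gives the same picture when hydrogen replaces it: this position can change the outcome, even though moving or adding a trifluoromethyl group on the ring produced no readable difference, and compound 4 is the only compound here with a true number rather than a limit. These steps give only the smallest possible size of the change, not its true size, because each one starts from a compound that sits at a limit: the limit of > 170000 nM in this assay, at which 2 of the 4 values shown sit, and (the limit of > 200000 nM in this assay, at which 1 of the 4 values shown sits).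

From the compounds shown here alone, what remains open is whether the lower number depends on hydrogen itself or simply on the absence of an aromatic ring, which a methyl group or a short chain ending in an amine on this nitrogen could help to separate. Going by these compounds, how far the three aryl compounds actually lie from compound 4 also stays unknown.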